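This account rests on a few compounds, and the source may have more. Where it says the series, first, only, none or still open, it means among the compounds named here.

In a functional assay on T47D cells (Homo sapiens) for cytotoxicity, read by MTT assay (a lower number here means a stronger inhibitor, a higher number a weaker inhibitor), compound 1 (`COc1ccc(C(=O)/C=C/c2ccc(F)cc2)c(O)c1`) reads 21900 nM while compound 2 (`O=C(/C=C/c1ccc(F)cc1)c1ccc(O)cc1O`) reads 8310 nM and compound 3 (`O=C(/C=C/c1ccc(N2CCCC2)cc1)c1ccc(O)cc1O`) reads 6990 nM in the same test. On these numbers compound 2 lies level with compound 3 and under compound 1. Within the data shown here, two measured steps touch compound 2. One is a 2.6-fold lower number from compound 1 to compound 2 (0.42 log units; beyond the scatter) when hydrogen takes the place of methyl on an oxygen on an aromatic ring. The other is a 1.2-fold lower number from compound 2 to compound 3 (0.08 log units; within the scatter) when pyrrolidin-1-yl takes the place of fluoro on an aromatic carbon.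

Compound 4 (`O=C(/C=C/c1ccc(F)cc1)c1ccc(O)cc1`) departs from compound 2 by a single change (hydrogen in place of hydroxy on an aromatic carbon) in which hydrogen stands in place of hydroxy on an aromatic carbon, ortho to a large group and meta to a hydroxy group. Among the measured compounds shown here, no measured step removes this hydroxy, so the guide is only indirect. The closest one is the modest 2.6-fold lower number from compound 1 to compound 2 (0.42 log units; beyond the scatter) where the compound with the free hydroxy carries the lower number. The second step, on the fluoro position, says nothing about this change. A modest rise of similar size is therefore expected, with wide uncertainty. The expected change is a 2.2-fold higher number from compound 2 to compound 4 (0.34 log units; beyond the scatter) in this assay as estimated here. The estimate for compound 4 is 18000 nM (expected range 7000 nM to 45000 nM).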

Compound 4, half-maximal inhibitory concentration: 13800 nM
Estimate against measurement, compound 4: 1.3-fold (0.12 log units) above; measured number inside the range.
By their numbers in this assay, from the lowest: compounds 3, 2, 4 and 1 (each within the scatter of the next, the first and the last beyond it).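

In this assay, the hydroxy ortho to a large group now has a direct reading of its own: a 1.7-fold higher number from compound 2 to compound 4 (0.22 log units; within the scatter), so hydrogen in its place leaves the number within the usual scatter of this test. Among these compounds, the earlier step on an oxygen of this ring, a 2.6-fold lower number from compound 1 to compound 2 (0.42 log units; beyond the scatter), lies beyond the scatter, but it concerns the other hydroxy, the one that remains in compound 4, and a methyl rather than a removal, so it cannot stand in for a reading at this position. No measurement shown here offers an explanation for the result.

What the compounds leave open is whether this position tolerates groups other than hydroxy and hydrogen, since a methoxy, an amine or a carboxylic acid on this aromatic carbon would each be a separate test. Among the compounds shown here, it also remains open whether hydrogen at this position would read the same with pyrrolidin-1-yl in place of fluoro, as the single step here was taken only with the fluoro group present.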